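Hexyl replaces sec-butyl on the propargylic ether carbon

This account rests on a few compounds, and the source may have more. Where it says the series, first, only, none or still open, it means among the compounds named here.

Three compounds of this series have numbers in a functional assay on SW1573 cells (Homo sapiens) for antiproliferative activity, read by sulforhodamine B assay, with a stated time of 48 h; a higher number here means a weaker inhibitor of growth, a lower number a stronger inhibitor of growth. Compound 1 `COC(=O)C#CC(O/C=C/C(=O)OC)C1CC1` gives 1800 nM. Compound 2 `CCCCCCCCCCC(C#CC(=O)OC)O/C=C/C(=O)OC` gives 2000 nM. Compound 3 `CCC(C)C(C#CC(=O)OC)O/C=C/C(=O)OC` gives 910 nM, the lowest of the three numbers; its gap to compound 1 lies within the scatter, while its gap to compound 2 lies just beyond it. Among the compounds with values here, the one step with a single change, a 2.0-fold lower number from compound 1 to compound 3 (0.30 log units; within the scatter), is itself within the scatter, so the three measured numbers show no clear trend with the group at this position.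

Compound 4 `CCCCCCC(C#CC(=O)OC)O/C=C/C(=O)OC` is not yet measured. hexyl in place of sec-butyl on a saturated chain carbon bound to an oxygen on an unsaturated carbon and a triple-bonded carbon Only compound 2 and compound 3, which carry different alkyl groups at the same place, speak to a change of this kind, and their two values differ by only slightly more than the scatter. Compound 4 is therefore expected to land between those two, with a small rise in number and a correspondingly weaker inhibition of growth as the most likely outcome. This amounts to an expected 1.4-fold higher number from compound 3 to compound 4 (0.15 log units; within the scatter), a step that may itself fall within the scatter. Compound 4 is estimated at 1300 nM, with a range from 600 nM to 2800 nM.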

Compound 4, concentration for 50% growth inhibition: 3300 nM
Compound 4: the middle estimate sits 2.5-fold (0.40 log units) below what was measured; measured number outside the range, above it.
By their numbers in this assay, from the lowest: compounds 3, 1, 2 and 4 (each within the scatter of the next, the first and the last beyond it).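

In this assay, within the data shown here, hexyl in place of sec-butyl gives a 3.6-fold higher number from compound 3 to compound 4 (0.56 log units; beyond the scatter) and is the first single change at this position to pass the scatter. The other two steps do not separate the compounds: hydrogen in place of butyl on the chain gives a 1.7-fold higher number from compound 2 to compound 4 (0.22 log units; within the scatter) and hexyl in place of cyclopropyl gives a 1.8-fold higher number from compound 1 to compound 4 (0.26 log units; within the scatter) so compound 4 cannot be told apart from compound 2 or compound 1, and chain length beyond hexyl shows no readable effect. The low number of compound 3 thus stands clear of the hexyl group of compound 4 and the longer straight chain of compound 2, but not of the cyclopropyl group of compound 1, whose gap to compound 3 stays within the scatter.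

No measurement at hand bears on why sec-butyl and hexyl differ here. Still open, going by these compounds, is whether the lower number goes with branching or with the smaller chain, which a straight butyl group or a tert-butyl group at this carbon would test, and how an amine or a carboxylic acid at the end of the chain would read.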